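Adding a nitro group to an inactive compound

A few compounds are considered here, and "the series" means these few. Any claim that something is new, unique, unknown or untested is made for them only; others in the source may bear on it.

Values so far in a functional assay, read by spectrophotometry, with a stated time of 5 min (on this read-out lower numbers stand for stronger inhibition and higher numbers for weaker inhibition), for three compounds:
compound 1 `O=c1[nH]c2ccccc2cc1/C=N/O` gives 463000 nM
compound 2 `O=c1[nH]c2ccccc2cc1/C=N/Nc1ccc([N+](=O)[O-])cc1` gives "not active" (no number reported)
compound 3 `O=c1[nH]c2ccccc2cc1/C=N/Nc1ccccc1` gives 306000 nM

Compound 1 and compound 3 both return a number, and those two numbers lie within the usual scatter of each other. Compound 2 stands apart, as it has no single number in this assay to place beside them. Compound 4 `O=c1[nH]c2ccccc2cc1/C=N/Nc1ccc([N+](=O)[O-])cc1[N+](=O)[O-]` has yet to be measured. The change under consideration is nitro in place of hydrogen on an aromatic carbon and it sets nitro in place of hydrogen on an aromatic carbon, ortho to a large group and meta to a nitro group.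

Among the measured compounds shown here, no measured pair in this small series shows the size of such a change. For the measured compounds named here, from a starting point without a number, no step toward stronger inhibition beyond the scatter is expected in this assay and the direction of any smaller shift cannot be read from the data. Compound 4 may well return no number at all, as compound 2 did. If a number does appear, the estimate for compound 4 is 500000 nM within an estimated range from 150000 nM to 1500000 nM in the same test.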

Compound 4, half-maximal inhibitory concentration: "not active" (no number reported)
Compound 4 has no reported number here; the estimate stays without a comparison.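

In this assay, among the compounds shown here, compound 2 and compound 4 both come back without a number, so no step between them can be read. Nothing shown here bears on this result. The compounds shown leave open what effect, if any, nitro in place of hydrogen on the aromatic carbon has on inhibition.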